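The source may report more compounds than this note shows. Statements on the series, on what has been measured and on what is new or still open speak of the compounds shown alone.

Measured compounds in an ADME assay on RAW264.7 cells (Mus musculus) for cytotoxicity, read by WST assay; on this read-out higher numbers stand for lower toxicity in this test and lower numbers for higher toxicity in this test:
- compound 1, `O=C(NCc1ccco1)c1ccc(CN2C(=O)c3ccccc3S2(=O)=O)cc1`, gives > 100000 nM, which is a limit of the assay rather than a number.
- compound 2, `CN(Cc1ccco1)C(=O)c1ccc(CN2C(=O)c3ccccc3S2(=O)=O)cc1`, gives > 100000 nM, likewise a limit and not a number.

Where compound 2 stands: in this assay it sits at the limit of > 100000 nM in this assay, at which 2 of the 2 values shown sit; no number is known for it, only the limit.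

For the measured compounds named here, the only measured step, a step that the two limits leave unreadable from compound 1 to compound 2, carries methyl in place of hydrogen on an amide-type nitrogen and cannot be read in size because both ends are limits.

The next compound, compound 3, `COC(=O)N(Cc1ccco1)C(=O)c1ccc(CN2C(=O)c3ccccc3S2(=O)=O)cc1`, differs from compound 2 by methoxycarbonyl in place of methyl on an amide-type nitrogen. The change again sits on the amide-type nitrogen, the same position touched by a step that the two limits leave unreadable from compound 1 to compound 2, and that step gave no readable size, so no direction can be drawn from it.

Expectation for this assay: no step beyond the scatter is expected, so a step that the limit leaves unreadable from compound 2 to compound 3 is taken as essentially flat, and compound 3 is estimated to remain at the limit. Compound 3 is therefore expected to give about 150000 nM, with a range from 50000 nM to 500000 nM, most likely reported again only as a limit.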

Compound 3, concentration lethal to 50% of the cells: > 100000 nM
Compound 3 was reported as a limit; the forecaster's own chance of this, stated with the estimate: 85%; the middle value is on the limit's open side.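

In this assay compound 3 gives > 100000 nM, which is a limit of the assay and not a number. The steps among compound 1, compound 2 and compound 3 therefore cannot be read: the limit of > 100000 nM in this assay, at which 3 of the 3 values shown sit.

The compounds shown leave open whether any change on the amide-type nitrogen moves the read-out in this assay at all, as none of the three gives a number.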